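The compounds below may be only part of what the source reports. "The series", "measured", "known", "first", "only" and "open" are said of these compounds alone.

Within the data shown here, in an ADME assay on Vero cells (Chlorocebus sabaeus) for cytotoxicity, read by resazurin assay, with a stated time of 72 h (on this read-out lower numbers stand for stronger inhibition and higher numbers for weaker inhibition), compound 3 (`O=C(CCN1CCN(c2ccc(F)cc2)CC1)c1ccc(OC(F)(F)F)cc1`) gives 70300 nM, the lowest number of the three measured so far. Compound 1 (`Cc1ccc(C(=O)CCN2CCN(c3ccc(Cl)cc3)CC2)cc1`) gives 184000 nM, and compound 2 (`COc1ccc(C(=O)CCN2CCN(c3ccc(Cl)cc3)CC2)cc1`) gives 300000 nM. Compound 4 (`O=C(CCN1CCN(c2ccc(Cl)cc2)CC1)c1ccc(OC(F)(F)F)cc1`) differs from compound 3 in one place: chloro in place of fluoro on an aromatic carbon. Among the measured compounds shown here, the only measured step, a 1.6-fold higher number from compound 1 to compound 2 (0.21 log units; within the scatter), is methoxy in place of methyl on an aromatic carbon. For the measured compounds named here, it lies within the scatter and is a different change, so it is a weak guide, and no measured step makes this exchange. No step beyond the scatter is therefore expected in this assay. The estimated change is a 1.1-fold higher number from compound 3 to compound 4 (0.03 log units; within the scatter). For compound 4 the estimated value is 75000 nM, with an expected range from 30000 nM to 180000 nM.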

Compound 4, half-maximal inhibitory concentration: 95600 nM
The estimate for compound 4 lay 1.3-fold (0.11 log units) below the measured number; the measured number falls inside the stated range.
By their numbers in this assay, from the lowest: compounds 3, 4, 1 and 2 (each within the scatter of the next, the first and the last beyond it).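

In this assay the change from 4-fluorophenyl to 4-chlorophenyl gives a step within the scatter (a 1.4-fold higher number from compound 3 to compound 4 (0.13 log units; within the scatter)), so at this position the two halogens are not told apart. With chloro held in place, trifluoromethyl in place of methyl on the oxygen gives a step beyond the scatter (a 3.1-fold lower number from compound 2 to compound 4 (0.50 log units; beyond the scatter)), whereas trifluoromethoxy in place of methyl on the aromatic carbon stays within it (a 1.9-fold lower number from compound 1 to compound 4 (0.28 log units; within the scatter)). Nothing available explains these numbers. From the compounds shown here alone, whether bromo, a nitrile or an amine at this position would keep the number in this range remains open, and so does whether the halogen exchange behaves alike with methyl or methoxy on the other ring.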